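Dichloro substitution on the hydrazone phenyl of the tetrazole series

A few compounds are considered here, and "the series" means these few. Any claim that something is new, unique, unknown or untested is made for them only; others in the source may bear on it.

Compound 1 `Cn1nnnc1SCC(=O)N/N=C/c1ccccc1` carries an unsubstituted phenyl and in an ADME assay on NIH3T3 cells (Mus musculus) for cytotoxicity, read by XTT assay, with a stated time of 24 h (on this read-out lower numbers stand for stronger inhibition and higher numbers for weaker inhibition), compound 1 gives 9700000 nM. Compound 2 `Cn1nnnc1SCC(=O)N/N=C/c1ccc(Cl)cc1` gives 2100000 nM in this assay, so a 4.6-fold lower number from compound 1 to compound 2 (0.66 log units; beyond the scatter). Compound 3 `Cn1nnnc1SCC(=O)N/N=C/c1ccccc1Cl` reaches only the limit of this assay, > 10000000 nM, and no number is available for compound 3; an at least 1.0-fold higher number from compound 1 to compound 3 (0.01 log units; that floor lies within the scatter), with the limit of > 10000000 nM in this assay, at which 1 of the 3 values shown sits, marking where that value sits. Compound 3 therefore stands at the weak end of the numbers shown, with only a floor known.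

Compound 4 `Cn1nnnc1SCC(=O)N/N=C/c1ccc(Cl)cc1Cl` differs from compound 3 by chloro in place of hydrogen on an aromatic carbon. The step that bears on this is the one in which the same chloro entered compound 2, which was modest; the step to compound 3 gave no change beyond the scatter. A modest lowering in this assay is therefore expected, though compound 3 offers only a limit to start from. Compound 4 is estimated at 4000000 nM, within 1500000 nM to 12000000 nM, which means an expected step of an at least 2.5-fold lower number from compound 3 to compound 4 (0.39 log units; beyond the scatter).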

Compound 4, half-maximal inhibitory concentration: 2140000 nM
Estimate against measurement, compound 4: 1.9-fold (0.27 log units) above; the range from low to high includes it.
By their numbers in this assay, from the lowest: compounds 2 and 4 (each within the scatter of the next); then compound 1. At a limit, above all of these: compound 3.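

In this assay the chloro that enters para to a large group, meta to a chloro group, gives an at least 4.6-fold lower number from compound 3 to compound 4 (0.66 log units; beyond the scatter), so the lowering seen on the unsubstituted phenyl also appears with a chloro already on the ring. The other chloro, entering on the core of compound 2, gives a 1.0-fold higher number from compound 2 to compound 4 (0.01 log units; within the scatter), so in the compounds shown only the chloro at the first place separates the numbers. Set side by side, the steps at that place read: the same change on two cores in this assay, a 4.6-fold lower number (0.66 log units; beyond the scatter) from compound 1 to compound 2 and an at least 4.6-fold lower number (0.66 log units; beyond the scatter) from compound 3 to compound 4; the limit leaves it open whether they differ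

As far as these compounds go, compound 3 stands at a limit, so the full size of its step stays open. From the compounds shown here alone, whether an amine, a carboxylic acid or a longer chain at this place would give the same lowering also stays open.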